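Replacing an isothiazole with a chlorophenyl on the shared core

The source may hold more compounds than are shown below. What is called first, only, known or untested is meant among the compounds shown, and "the series" means these compounds.

Among the measured compounds shown here, compound 1 `COc1nc(-c2cnsc2)ccc1[C@@H](c1ccccc1)[C@@](O)(CCN(C)C)c1cccc2ccccc12` stands at the higher end of the two numbers so far: in a toxicity assay on HeLa cells (Homo sapiens) for cytotoxicity (on this read-out lower numbers stand for higher toxicity in this test and higher numbers for lower toxicity in this test), compound 1 gives 28.8 ug/mL. Compound 2 `COc1ncc(-c2ccccc2)cc1[C@@H](c1ccccc1)[C@@](O)(CCN(C)C)c1cccc(F)c1F` sits alongside it, since in this assay compound 2 gives 28.1 ug/mL, a gap within the scatter. Compound 3 `COc1nc(-c2ccccc2Cl)ccc1[C@@H](c1ccccc1)[C@@](O)(CCN(C)C)c1cccc2ccccc12` carries one change from compound 1: 2-chlorophenyl in place of 1,2-thiazol-4-yl on an aromatic carbon. For the measured compounds named here, with no measured step of this kind, the step of a 1.3-fold lower number from compound 1 to compound 3 (0.12 log units; within the scatter) is expected to be small, a modest move toward a lower number at most. Compound 3 is therefore expected to give about 22 ug/mL, within a range from 10 ug/mL to 45 ug/mL.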

Compound 3, half-maximal cytotoxic concentration: > 64 ug/mL
Compound 3 gave a limit, no number; the forecaster's own chance of this, stated with the estimate: 5%; middle value at least 2.9-fold (0.46 log units) away from the limit.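

On the shared core, the aromatic carbon next to the ring nitrogen proves sensitive to its substituent in this assay, where 2-chlorophenyl in place of 1,2-thiazol-4-yl gives an at least 2.2-fold higher number from compound 1 to compound 3 (0.34 log units; beyond the scatter). Among the compounds shown here, this is the first step at this position, and it moves toward lower toxicity in this test. The reading for compound 3 is a limit of the assay and not a number: the limit of > 64 ug/mL in this assay, at which 1 of the 3 values shown sits.

Going by these compounds, how far compound 3 lies past that limit remains open. So does whether the chlorine or the ring carries the step, and whether a pyridyl or an aminophenyl at this place would move the number in the same direction.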